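The source may report more compounds than this note shows. Statements on the series, on what has been measured and on what is new or still open speak of the compounds shown alone.

Compound 1 `COc1ccc(CNCCCNS(=O)(=O)c2cc(C(F)(F)F)cc(C(F)(F)F)c2)cc1OC` and compound 2 `CC(C)(C)c1ccc(CNCCCNS(=O)(=O)c2cc(C(F)(F)F)cc(C(F)(F)F)c2)cc1` share one core and differ only in the aryl group on the chain. In a functional assay on A-431 cells (Homo sapiens) for inhibition, read by MTT assay, with a stated time of 72 h (a higher number here means a weaker inhibitor of growth, a lower number a stronger inhibitor of growth), compound 1 gives 7000 nM, and compound 2 gives 2800 nM; the step of a 2.5-fold lower number from compound 1 to compound 2 (0.40 log units; beyond the scatter) is the only one measured, so compound 2 stands lowest of the two numbers. Compound 3 `O=S(=O)(NCCCNCc1ccc(-c2ccccc2)cc1)c1cc(C(F)(F)F)cc(C(F)(F)F)c1` carries the change (phenyl in place of tert-butyl on an aromatic carbon). For the measured compounds named here, no measured step tests this exchange, and the one step known, a 2.5-fold lower number from compound 1 to compound 2 (0.40 log units; beyond the scatter), is modest, so only a small shift, if any, is expected: the step of a 1.3-fold lower number from compound 2 to compound 3 (0.10 log units; within the scatter) is the estimate. Compound 3 is therefore expected near 2200 nM, between 800 nM and 6500 nM.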

Compound 3, concentration for 50% growth inhibition: 2600 nM
Estimate against measurement, compound 3: 1.2-fold (0.07 log units) below, within the range that was stated.
By their numbers in this assay, from the lowest: compounds 3 and 2 (each within the scatter of the next); then compound 1.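

In this assay, the exchange of tert-butyl for phenyl on an aromatic carbon, para to a large group, gives a 1.1-fold lower number from compound 2 to compound 3 (0.03 log units; within the scatter). At this position, therefore, a six-membered aromatic ring of carbon only and a branched group without a ring read alike, a finding the earlier step from the 3,4-dimethoxyphenyl compound could not give. Nothing available explains this equivalence. Still open, going by these compounds, is whether a carboxylic acid or an amine on this aromatic carbon would read the same. Also open, on these data alone, is how a pyridine ring in place of phenyl, or a longer chain, would read.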